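Swapping the pendant heteroaryl on the piperazine of compound 1

This account rests on a few compounds, and the source may have more. Where it says the series, first, only, none or still open, it means among the compounds named here.

In a functional assay on A-375 cells (Homo sapiens) for antiproliferative activity, read by CCK-8 assay, with a stated time of 72 h, tested at 2 uM (on this read-out lower numbers stand for a weaker effect and higher numbers for a stronger effect at the one concentration tested), compound 1 `Nc1ccccc1NC(=O)c1ccc(CSC(=S)N2CCN(Cc3ccccn3)CC2)cc1` gives 20.7%, the lowest of the three measured numbers. Compound 2 `CC1CCCCN1C(=S)SCc1ccc(C(=O)Nc2ccccc2N)cc1` gives 42.5% and compound 3 `CC1CCN(C(=S)SCc2ccc(C(=O)Nc3ccccc3N)cc2)CC1` gives 32.7% in this assay, so compound 1 sits beyond the scatter below both of them. Among the measured compounds shown here, the only measured step, a number 9.8 percentage points lower from compound 2 to compound 3 (within the scatter), concerns the group on the thiocarbonyl carbon, which is exchanged between a 2-methylpiperidin-1-yl and a 4-methylpiperidin-1-yl, and stays within the scatter.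

Compound 4 `Nc1ccccc1NC(=O)c1ccc(CSC(=S)N2CCN(c3cnccn3)CC2)cc1` differs from compound 1 in a different part of the molecule: pyrazin-2-yl in place of (pyridin-2-yl)methyl on an amine nitrogen in a ring. For the measured compounds named here, no measured pair touches the group on the ring amine nitrogen, so the step from compound 1 to compound 4 has no direct precedent here, and the one step that is known was flat. Given that, a large move is not anticipated; compound 4 is expected to give about 24% in this assay. The estimated range for compound 4 runs from 10% to 42%. This amounts to an expected step of a number 3.3 percentage points higher from compound 1 to compound 4 (within the scatter), which is judged not to exceed the scatter.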

Compound 4, a percentage reported as inhibition, at one concentration (the size of the read-out at that concentration, not a potency): 29.1%
Beside the measured number, compound 4's estimate is 5.1 percentage points below it; measured number inside the range.
By their numbers in this assay, from the lowest: compounds 1, 4, 3 and 2 (each within the scatter of the next, the first and the last beyond it).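

In this assay, among the compounds shown here, the first measured change at the amine nitrogen in a ring, pyrazin-2-yl in place of (pyridin-2-yl)methyl, gives a number 8.4 percentage points higher from compound 1 to compound 4 (within the scatter) and so leaves the read-out unresolved at this position. The exchange alters two things at once, the hetero atoms in the six-membered aromatic ring and the methyl link to that ring, and this single step cannot separate them. Nothing available explains the size of this step.

The compounds shown leave open what pyridin-2-yl or (pyrazin-2-yl)methyl on this nitrogen would give, either of which would change only one of those two features. They also leave open whether a non-aromatic group there, such as a simple methyl or an acetyl, would produce a step beyond the scatter.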